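The source may hold more compounds than are shown below. What is called first, only, known or untested is meant among the compounds shown, and "the series" means these compounds.

Measured so far in a functional assay on HCT-116 cells (Homo sapiens) for antiproliferative activity, read by CCK-8 assay, with a stated time of 72 h; on this read-out lower numbers stand for stronger inhibition and higher numbers for weaker inhibition:
compound 1 `CCc1ccc(SCc2ccc(C(=O)Nc3ccccc3N)cc2)cc1`: 1740 nM
compound 2 `Nc1ccccc1NC(=O)c1ccc(CSc2nccc(C(F)(F)F)n2)cc1`: 1140 nM

Compound 1 holds the higher of the two numbers, but its gap to compound 2 lies within the scatter, so the two are not separated in this assay. Compound 3 `Cc1cc(C)cc(SCc2ccc(C(=O)Nc3ccccc3N)cc2)c1` differs from compound 1 in one place: 3,5-dimethylphenyl in place of 4-ethylphenyl on a sulfur. Among the compounds with values here, no step between measured compounds covers a change of this kind, so nothing here points to a direction, and the change is expected to stay within the scatter of this assay. The expected step is a 1.0-fold lower number from compound 1 to compound 3 (0.01 log units; within the scatter), small. For compound 3 the estimate is 1700 nM, with a range from 800 nM to 3600 nM.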

Compound 3, half-maximal inhibitory concentration: 2490 nM
Estimate against measurement, compound 3: 1.5-fold (0.17 log units) below; low and high end bracket the measured number.
By their numbers in this assay, from the lowest: compounds 2, 1 and 3 (each within the scatter of the next, the first and the last beyond it).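

In this assay the change on the sulfur gives a 1.4-fold higher number from compound 1 to compound 3 (0.16 log units; within the scatter) and does not separate the two compounds. Moving from 4-ethylphenyl to 3,5-dimethylphenyl keeps the same eight carbons and a single aromatic ring, and at this position the rearrangement leaves the two numbers unresolved. No measurement bears on the cause of this step. Still open, from the compounds shown here alone, is whether a non-hydrocarbon group on this aryl ring, such as an amine or a carboxylic acid, would give a step beyond the scatter. Going by these compounds, a longer chain in place of the ethyl is equally open.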